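The compounds below may be only part of what the source reports. "The series", "measured", "known", "first", "only" and "open" are said of these compounds alone.

Measured so far in a functional assay on DU-145 cells (Homo sapiens) for inhibition, read by trypan blue exclusion, with a stated time of 96 h; a higher number here means a weaker inhibitor of growth, a lower number a stronger inhibitor of growth:
compound 1 `CSc1ccc(/C=C(\C(=O)c2ccc(Cl)cc2)S(=O)(=O)Cc2ccc(C)cc2)cc1`: 10000 nM
compound 2 `CSc1ccc(/C=C(\C(=O)c2ccc(Br)cc2)S(=O)(=O)Cc2ccc(C)cc2)cc1`: 10000 nM
compound 3 `COc1ccc(S(=O)(=O)/C(=C/c2ccc(Cl)cc2Cl)C(=O)c2ccc(Br)cc2)cc1`: 20000 nM

Compound 1 is level with compound 2 and sits within the scatter of compound 3; none of the three can be called stronger or weaker than another. Among the measured compounds shown here, the only single-point step on record, no change at the digits printed from compound 1 to compound 2 (within the scatter), is bromo in place of chloro on an aromatic carbon. Compound 4 `Cc1ccc(CS(=O)(=O)/C(=C/c2c[nH]c3ccc(Br)cc23)C(=O)c2ccc(Cl)cc2)cc1` differs from compound 1 by 5-bromo-1H-indol-3-yl in place of 4-(methylsulfanyl)phenyl on a double-bonded chain carbon bound to a double-bonded chain carbon. For the measured compounds named here, no measured step touches this part of the core, so the halogen swap gives no guide to size or direction, and the three values show no sensitivity anywhere. The expected step of no change at the digits printed from compound 1 to compound 4 (within the scatter) is therefore none beyond the scatter. In this assay compound 4 is estimated at 10000 nM, within 3000 nM to 30000 nM.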

Compound 4, concentration for 50% growth inhibition: 10000 nM
Compound 4: middle estimate and measured number agree at the digits printed; measured number inside the range.
By their numbers in this assay, from the lowest: compounds 1, 2, 4 and 3 (each within the scatter of the next).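

In this assay, 5-bromo-1H-indol-3-yl in place of 4-(methylsulfanyl)phenyl gives no change at the digits printed from compound 1 to compound 4 (within the scatter). This position, on a double-bonded chain carbon bound to a double-bonded chain carbon, therefore accepts a second aromatic ring, a bromine and a hydrogen-bond donor together, without a shift beyond the scatter. No evidence bearing on this result is available.

Still open, on these data alone, is whether a group without an aromatic ring here, such as a short alkyl chain, or a phenyl carrying an amine or a carboxylic acid, would move the number beyond the scatter.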